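The source may hold more compounds than are shown below. What is called first, only, known or untested is meant among the compounds shown, and "the series" means these compounds.

Three compounds have been measured in a functional assay on HT-29 cells (Homo sapiens) for inhibition, read by MTT assay, with a stated time of 120 h; a lower number here means a stronger inhibitor, a higher number a weaker inhibitor:

Compound 1, `O=C(CCc1ccc(NC(=O)Nc2ccc(Cl)c(C(F)(F)F)c2)cc1)NC1CCC1`, gives 21300 nM.
Compound 2, `CNC(=O)c1cccc(-c2ccc(NC(=O)Nc3ccc(Cl)c(C(F)(F)F)c3)cc2)c1`, gives 29300 nM.
Compound 3, `CNC(=O)CCc1ccc(NC(=O)Nc2ccc(Cl)c(C(F)(F)F)c2)cc1`, gives 20600 nM.

Compound 3 has the lowest of the three numbers, but the step from compound 1 to compound 3 is a 1.0-fold lower number from compound 1 to compound 3 (0.01 log units; within the scatter) and the step from compound 2 to compound 3 is a 1.4-fold lower number from compound 2 to compound 3 (0.15 log units; within the scatter), so the three compounds cannot be told apart on these numbers. Compound 4, `CC1CN(C(=O)CCc2ccc(NC(=O)Nc3ccc(Cl)c(C(F)(F)F)c3)cc2)CC(C)O1`, differs from compound 3 in one place: 2,6-dimethylmorpholin-4-yl in place of methylamino on a carbonyl carbon. Within the data shown here, the step that bears most on this is the one from compound 1 to compound 3, a 1.0-fold lower number from compound 1 to compound 3 (0.01 log units; within the scatter), where the group on the amide-type nitrogen was also exchanged without effect beyond the scatter. The exchange of the whole side chain, a 1.4-fold lower number from compound 2 to compound 3 (0.15 log units; within the scatter), likewise stayed within the scatter. The expectation for compound 4 is therefore a step of a 1.0-fold higher number from compound 3 to compound 4 (0.01 log units; within the scatter), nothing beyond the scatter. Compound 4 is estimated at 21000 nM, with a range from 8000 nM to 60000 nM.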

Compound 4, half-maximal inhibitory concentration: > 50000 nM
Compound 4: only a limit was reported; the forecaster's own chance of this, stated with the estimate: 10%; middle value at least 2.3-fold (0.37 log units) away from the limit.
By their numbers in this assay, from the lowest: compounds 3, 1 and 2 (each within the scatter of the next). At a limit, above all of these: compound 4.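

In this assay, compound 4 gives only a limit, not a number: the limit of > 50000 nM in this assay, at which 1 of the 4 values shown sits.

Even so, the group on this carbonyl carbon is now shown to matter: exchanging cyclobutylamino for methylamino gave a 1.0-fold lower number from compound 1 to compound 3 (0.01 log units; within the scatter), whereas 2,6-dimethylmorpholin-4-yl gives an at least 2.4-fold higher number from compound 3 to compound 4 (0.38 log units; beyond the scatter), and against cyclobutylamino it gives an at least 2.3-fold higher number from compound 1 to compound 4 (0.37 log units; beyond the scatter). Unlike both earlier groups, 2,6-dimethylmorpholin-4-yl has no hydrogen-bond donor, and its nitrogen is part of a six-membered ring that also holds an oxygen and carries two methyl groups.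

All of these features change together, so the compounds shown leave open which of them goes with the step. Dimethylamino, with no amide hydrogen and no ring, and plain morpholin-4-yl, without the two methyl groups, would help separate them.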